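This account rests on a few compounds, and the source may have more. Where it says the series, first, only, none or still open, it means among the compounds named here.

Three compounds of the series carry numbers in a functional assay on A549 cells (Homo sapiens) for cytotoxicity, read by MTT assay, with a stated time of 72 h (a lower number here means a stronger inhibitor, a higher number a weaker inhibitor), so far. Compound 1 `COc1ccccc1-c1cc(=O)c2c(O)cc(OCCCCN3CCN(C)CC3)c(OC)c2o1` gives 6790 nM. Compound 2 `CN(C)CCCOc1c(OCc2ccccc2)cc(O)c2c(=O)cc(-c3ccccc3)oc12` gives 2910 nM. Compound 3 `CCN(CC)CCCOc1c(OCc2ccccc2)cc(O)c2c(=O)cc(-c3ccccc3)oc12` gives 3620 nM, the second highest of the three numbers, with compound 2 nearest and compound 1 furthest, both differences within the scatter. Compound 4 `O=c1cc(-c2ccccc2)oc2c(OCCCN3CCCC3)c(OCc3ccccc3)cc(O)c12` is not yet measured; it differs from compound 3 by pyrrolidin-1-yl in place of diethylamino on a saturated chain carbon, three bonds along the chain from an oxygen on an aromatic ring. For the measured compounds named here, the one measured step at that position is a 1.2-fold higher number from compound 2 to compound 3 (0.09 log units; within the scatter), an exchange of one amine for another that stayed within the scatter. On that single precedent no shift beyond the scatter is expected here, so compound 4 is estimated at 3500 nM, with a range of 1500 nM to 8000 nM. That estimate means an expected step of a 1.0-fold lower number from compound 3 to compound 4 (0.01 log units; within the scatter).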

Compound 4, half-maximal inhibitory concentration: 4720 nM
For compound 4 the middle estimate is 1.3-fold (0.13 log units) below the measured one; the range from low to high includes it.
By their numbers in this assay, from the lowest: compounds 2, 3, 4 and 1 (each within the scatter of the next, the first and the last beyond it).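

In this assay the ring closure gives a 1.3-fold higher number from compound 3 to compound 4 (0.12 log units; within the scatter) for pyrrolidin-1-yl in place of diethylamino on the same count of heavy atoms. For the compounds shown here, measured against dimethylamino, the same ring gives a 1.6-fold higher number from compound 2 to compound 4 (0.21 log units; within the scatter) and so the chain end now accepts a cyclic amine as well as two open ones, with no step among the three beyond the scatter. No supporting data bear on why this position responds so little.

As far as these compounds go, whether piperidin-1-yl or morpholin-4-yl would also stay within the scatter remains open. So does the effect of a longer chain carrying pyrrolidin-1-yl.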